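Side-chain change from compound 3 to compound 4

The source may report more compounds than this note shows. Statements on the series, on what has been measured and on what is new or still open speak of the compounds shown alone.

Among the measured compounds shown here, compound 3 `NC(=O)[C@H](CO)Nc1cc(=O)oc2cc(OCc3cccc(Cl)c3)ccc12` gives 2400 nM in an assay for inhibition of Amine oxidase [flavin-containing] B (Rattus norvegicus) (a higher number here means a weaker inhibitor, a lower number a stronger inhibitor), the second highest of the three numbers measured so far; compound 1 `C[C@H](Nc1cc(=O)oc2cc(OCc3ccccc3)ccc12)C(N)=O` gives 680 nM and compound 2 `NC(=O)[C@@H]1CCCN1c1cc(=O)oc2cc(OCc3ccccc3)ccc12` gives 16100 nM. Compound 4 `NC(=O)Cc1cc(=O)oc2cc(OCc3cccc(Cl)c3)ccc12` differs from compound 3 by carbamoylmethyl in place of (1-carbamoyl-2-hydroxyethyl)amino on an aromatic carbon. For the measured compounds named here, the only measured step, a 24-fold higher number from compound 1 to compound 2 (1.37 log units; beyond the scatter), alters the same side chain but is a different change, so it bears only loosely on this one; here the side chain is shortened rather than closed into a ring. Compound 4 is therefore expected to weaken somewhat, with a step of a 1.9-fold higher number from compound 3 to compound 4 (0.27 log units; within the scatter) estimated. The estimate for compound 4 is 4500 nM, within a range of 1200 nM to 17000 nM.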

Compound 4, half-maximal inhibitory concentration: 30 nM
Estimate against measurement, compound 4: 150-fold (2.18 log units) above; the measured number lies below the stated range.
By their numbers in this assay, from the lowest: compound 4; then compound 1; then compound 3; then compound 2.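

In this assay, the largest gain so far at the aromatic carbon opposite the ring oxygen comes with carbamoylmethyl in place of (1-carbamoyl-2-hydroxyethyl)amino: an 80-fold lower number from compound 3 to compound 4 (1.90 log units; beyond the scatter). The earlier compounds shown here showed only a loss on changing this side chain; here the number falls sharply with a smaller side chain that has no defined stereocentre. No supporting data bear on the origin of this gain.

The change removes the amino nitrogen and the hydroxymethyl branch together, so their separate contributions remain unresolved. Going by these compounds, how a carboxylic acid or a longer chain ending in the same amide would compare with compound 4 also remains open.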